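The source may hold more compounds than are shown below. What is called first, only, known or untested is meant among the compounds shown, and "the series" means these compounds.

In a physicochemical assay for solubility, with a stated time of 3 days, at pH 2 (a lower number here means a less soluble compound, a higher number a more soluble compound), compound 1 `NC(=O)c1ccc2[nH]c(-c3ccc(OCCCO)cc3)nc2c1` gives 185000 nM as a true number. Compound 2 `NC(=O)c1ccc2[nH]c(-c3ccc(OCCCN4CCCCC4)cc3)nc2c1` gives > 400000 nM and that is a limit of the assay, not a number. Compound 3 `CC(=O)N1CCC(COc2ccc(-c3nc4cc(C(N)=O)ccc4[nH]3)cc2)CC1` has "not determined" (no result reported) as its entry, so it has no place on this scale and offers no number to start from.

Compound 4 `CC(=O)N1CCCCC1CCOc1ccc(-c2nc3cc(C(N)=O)ccc3[nH]2)cc1` differs from compound 3 in one place ((1-acetylpiperidin-2-yl)methyl in place of 1-acetylpiperidin-4-yl on a saturated chain carbon bound to an oxygen on an aromatic ring) with (1-acetylpiperidin-2-yl)methyl in place of 1-acetylpiperidin-4-yl on a saturated chain carbon bound to an oxygen on an aromatic ring. Both groups hold one six-membered non-aromatic ring with 1 hetero atom and carry no net charge.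

For the measured compounds named here, the only measured step is an at least 2.1-fold higher number from compound 1 to compound 2 (0.33 log units; beyond the scatter) where piperidin-1-yl stands in place of hydroxy on a saturated chain carbon, three bonds along the chain from an oxygen on an aromatic ring. That step swaps a different pair of groups, so it gives no size for this change, and no step beyond the usual scatter is expected in this assay on going from compound 3 to compound 4. Going by the values given here, with compound 1 at 185000 nM as the only true number, the estimate stays close to it. For compound 4 the expected value is 200000 nM with an estimated range from 70000 nM to 400000 nM in this measurement.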

Compound 4, solubility: > 400000 nM
Compound 4: only a limit was reported (the forecaster's own chance of this, stated with the estimate: 25%); at least 2.0-fold (0.30 log units) between middle value and limit.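

In this assay, compound 4 gives > 400000 nM, and that is a limit of the assay, not a number. For the compounds shown here, with 1-acetylpiperidin-2-yl in place of hydroxymethyl at this place on the chain, the result is an at least 2.1-fold higher number from compound 1 to compound 4 (0.33 log units; beyond the scatter), so a group with no net charge now also shows a step beyond the scatter, and piperidin-1-yl is no longer the only group at the end of this chain to do so. The step between compound 2 and compound 4 cannot be read, and the two stay unordered on this scale: the limit of > 400000 nM in this assay, at which 2 of the 4 values shown sit.

No pair shown differs only in the acetyl group on the piperidine ring, so its share in the step remains open, and the true value of compound 4 remains unknown. Also open, as far as these compounds go, is where a carboxylic acid, a morpholin-4-yl group or a longer chain ending in a primary amine would fall at this place, and whether any of them would give a true number rather than a limit.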